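Chloro substitution on the fused ring of compound 3

A few compounds are considered here, and "the series" means these few. Any claim that something is new, unique, unknown or untested is made for them only; others in the source may bear on it.

Within the data shown here, compound 3 `O=S(=O)(NCCN1CCC(CNC2CCCc3ccccc3C2)CC1)c1cccc2ccccc12` sits at the weaker end of the numbers measured so far. In an assay on isolated protein for inhibition of Neuropeptide Y receptor type 5 (Homo sapiens) (on this read-out lower numbers stand for stronger inhibition and higher numbers for weaker inhibition), compound 3 gives 210 nM. Among the measured compounds shown here, its nearest neighbour, compound 2 `COc1ccc2c(c1)CC(NCC1CCN(CCNS(=O)(=O)c3cccc4ccccc34)CC1)CCC2`, gives 45 nM in this assay, and the step of a 4.7-fold higher number from compound 2 to compound 3 (0.67 log units; beyond the scatter) is the only single-point change among the measured compounds. Compound 1 `COc1cccc2c1CCCC(NCCN1CCC(CNS(=O)(=O)c3cccc4ccccc34)CC1)C2` reaches only a limit in this assay, > 1000 nM, and that limit is a boundary of the assay rather than a number (the limit of > 1000 nM in this assay, at which 1 of the 3 values shown sits).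

Compound 4 `O=S(=O)(NCCN1CCC(CNC2CCCc3ccc(Cl)cc3C2)CC1)c1cccc2ccccc12` differs from compound 3 by chloro in place of hydrogen on an aromatic carbon. For the measured compounds named here, the one measured step on the same fused ring, a 4.7-fold higher number from compound 2 to compound 3 (0.67 log units; beyond the scatter), concerns a different group, methoxy rather than chloro, and runs as a removal rather than an addition, so it bears on the question only loosely. It shows that a single substituent on this ring can shift the number beyond the scatter, but it gives no direction for a chloro group at this carbon. A change of modest size is therefore expected, with the direction left open. Compound 4 is expected to give 150 nM in this assay, within 50 nM to 500 nM. The expected step of a 1.4-fold lower number from compound 3 to compound 4 (0.15 log units; within the scatter) is accordingly treated as small and undecided in sign.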

Compound 4, half-maximal inhibitory concentration: 85 nM
Estimate against measurement, compound 4: 1.8-fold (0.25 log units) above; low and high end bracket the measured number.
By their numbers in this assay, from the lowest: compounds 2 and 4 (each within the scatter of the next); then compound 3. At a limit, above all of these: compound 1.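

Chloro on this carbon of the fused ring moves the number in this assay beyond the scatter, with a 2.5-fold lower number from compound 3 to compound 4 (0.39 log units; beyond the scatter) as the step, so the direction left undecided for this change is now settled in favour of stronger inhibition. Methoxy at the same carbon points the same way, since a 4.7-fold higher number from compound 2 to compound 3 (0.67 log units; beyond the scatter) shows its replacement by hydrogen giving a weaker result, and the unsubstituted compound 3 therefore lies on the weaker side of both substituted compounds. The direct exchange of the two groups, a 1.9-fold higher number from compound 2 to compound 4 (0.28 log units; within the scatter) on this read-out, does not separate them, so the data show that substitution at this carbon matters but do not rank chloro against methoxy.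

The compounds shown leave open whether an amine or a carboxylic acid on this carbon would follow the same direction, and whether chloro on the other aromatic carbons of this ring would do so. Nothing given here measures a property that could account for the step, and its cause stays unassigned.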